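Removing the Bromo Group from Compound 1

The source may hold more compounds than are shown below. What is called first, only, known or untested is meant among the compounds shown, and "the series" means these compounds.

Measured in a functional assay on the whole organism for inhibition, with Scenedesmus acutus as the target; a lower number here means a stronger inhibitor, a higher number a weaker inhibitor:
compound 1 `S=c1s/c(=N\c2ccc(Br)cc2)n2n1CCCC2` gives 162 nM
compound 2 `CC(C)Oc1cc(/N=c2\sc(=S)n3n2CCCC3)c(F)cc1Cl` gives 13.8 nM
compound 3 `COC(=O)CSc1cc(-n2c(=S)n3n(c2=S)CCCC3)c(F)cc1Cl` gives 186 nM

Compound 1 and compound 3 lie within the usual scatter of each other, so this assay does not separate them. Compound 2 has a number well beyond the scatter on the lower side, which makes it a clearly stronger inhibitor than compound 1.

The next compound to be tested is compound 4 `S=c1s/c(=N\c2ccccc2)n2n1CCCC2`. It is compound 1 with hydrogen in place of bromo on an aromatic carbon, para to a large group: hydrogen in place of bromo on an aromatic carbon. Within the data shown here, no two measured compounds differ in one place only, so no measured step shows directly what this change does. The guide is thin. Compound 1 (162 nM) and the other two measured compounds all carry at least one halogen on the six-membered aromatic ring, and compound 4 would be the first without one. On that basis a weaker inhibitor is expected, with an estimated step of a 6.2-fold higher number from compound 1 to compound 4 (0.79 log units; beyond the scatter) that goes beyond the scatter towards a higher number. For compound 4 the expected value is 1000 nM, with an estimated range from 300 nM to 4000 nM.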

Compound 4, half-maximal inhibitory concentration: 14100 nM
The estimate for compound 4 lay 14-fold (1.15 log units) below the measured number; measured number outside the range, above it.
By their numbers in this assay, from the lowest: compound 2; then compounds 1 and 3 (each within the scatter of the next); then compound 4.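

In this assay, among these compounds, putting hydrogen in place of bromo on the aromatic carbon para to a large group gives an 87-fold higher number from compound 1 to compound 4 (1.94 log units; beyond the scatter), the first direct reading of a change at this position. The position is therefore far from indifferent: the loss of one heavy atom, with no change in the counts of hydrogen-bond donors, hydrogen-bond acceptors or net charge, is enough to turn compound 1 into a clearly weaker inhibitor. No measurement is available that explains what the bromo group contributes to this large step.

The compounds shown leave open whether bromine itself matters or whether other groups at this position, such as iodo, methyl, methoxy or nitrile, would hold the strength of compound 1 or even improve on it. On these data alone, it also remains open whether the same change would have a step of similar size on another core, and the other compounds differ from compound 1 in more than one place, so they cannot settle either question.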